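Anilino-thiazole series: cytotoxicity on RKO cells

This account rests on a few compounds, and the source may have more. Where it says the series, first, only, none or still open, it means among the compounds named here.

Measured so far:
compound 1, `c1ccc(Nc2nc(-n3cnc4ccccc43)cs2)cc1`, in a functional assay on RKO cells (Homo sapiens) for cytotoxicity, read by resazurin assay, with a stated time of 72 h (a lower number here means a stronger inhibitor, a higher number a weaker inhibitor), gives > 100000 nM, which is a limit of the assay rather than a number.
compound 2, `Cc1nc2ccccc2n1-c1csc(Nc2ccc(S(N)(=O)=O)cc2)n1`, in this assay gives 95000 nM.

Going by the values given here, compound 2 thus holds the only numeric value in this assay so far; the other result is a limit, as the limit of > 100000 nM in this assay, at which 1 of the 2 values shown sits, records for compound 1. Both entries sit at the weak end of what the assay can resolve.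

Compound 3, `Cc1nc2ccccc2n1-c1csc(Nc2ccccc2)n1`, is the next analogue. It differs from compound 2 in one place: hydrogen in place of sulfamoyl on an aromatic carbon. Among the compounds with values here, no pair of measured compounds shows this change, so its size is not known from the data. Compound 1 carries the same unsubstituted anilino part as compound 3 on a related core and returned only a limit in this assay.

Given that compound 2 already lies close to the assay ceiling, the step is expected to be a 1.2-fold higher number from compound 2 to compound 3 (0.06 log units; within the scatter), small or none beyond the scatter, and possibly toward the limit. Compound 3 is estimated at 110000 nM, within 50000 nM to 300000 nM.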

Compound 3, half-maximal inhibitory concentration: 50000 nM
Compound 3: middle estimate off by 2.2-fold (0.34 log units), on the high side; the measured number falls inside the stated range.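

In this assay, hydrogen in place of sulfamoyl on the aromatic carbon para to a large group gives a 1.9-fold lower number from compound 2 to compound 3 (0.28 log units; within the scatter), so this first reading of the change shows no effect that can be told from the scatter, and compound 3 still returns a number, 50000 nM. Methyl in place of hydrogen on an aromatic carbon, the one change between compound 1 and compound 3, gives an at least 2.0-fold lower number from compound 1 to compound 3 (0.30 log units; that floor lies within the scatter), which is a floor and not a full size. Compound 1 stands at a limit of the assay and not at a number: the limit of > 100000 nM in this assay, at which 1 of the 3 values shown sits.

Sulfamoyl and hydrogen are the only groups shown at the aromatic carbon para to a large group, so what an amine or a carboxylic acid there would give stays open. As far as these compounds go, the true size of the methyl step also stays open, as does whether a longer chain in place of that methyl would move the number beyond the scatter.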